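This account rests on a few compounds, and the source may have more. Where it says the series, first, only, none or still open, it means among the compounds named here.

Series notes. Compound 1 `CC(=O)Nc1nc(-c2cccc(NS(=O)(=O)c3cccc(Br)c3)c2)cs1` is recorded as "not active" (no number reported) in a functional assay on A-375 cells (Homo sapiens) for antiproliferative activity, read by trypan blue exclusion, with a stated time of 48 h, tested at 1 uM (on this read-out lower numbers stand for a stronger effect and higher numbers for a weaker effect at the one concentration tested), with no number attached. Going by the values given here, compound 2 `CCCCC#Cc1ccc(S(=O)(=O)Nc2cccc(-c3csc(NC(C)=O)n3)c2)cc1` gives 73.2% in this assay, the only number so far in this read-out, so it stands alone there, with one further entry that carries no number. Compound 3 `CCCCCCCCc1ccc(S(=O)(=O)Nc2cccc(-c3csc(NC(C)=O)n3)c2)cc1` differs from compound 2 by octyl in place of hex-1-yn-1-yl on an aromatic carbon. Among the compounds with values here, no measured pair isolates this change, so the expected step of a number 2.8 percentage points higher from compound 2 to compound 3 (within the scatter) is taken as small, not beyond the usual scatter. Compound 3 is accordingly expected at 76%, estimated to fall between 56% and 96%.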

Compound 3, a percentage reported as activity, at one concentration (the size of the read-out at that concentration, not a potency): 34.8%
Estimate against measurement, compound 3: 41.2 percentage points above; the whole stated range lies above it.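

Going by these compounds alone, on an aromatic carbon para to a large group, the substituent clearly changes the read-out in this assay as octyl in place of hex-1-yn-1-yl gives a number 38.4 percentage points lower from compound 2 to compound 3 (beyond the scatter) and provides the first readable step. The change both lengthens the chain and removes the triple bond, and this single step does not separate the two. Nothing measured here bears on the cause of the step.

Still open, from the compounds shown here alone, is whether hexyl, the saturated chain of the same length as hex-1-yn-1-yl, tracks compound 2 or compound 3. Also open, going by these compounds, is how a longer chain such as decyl, or an octyl chain ending in a carboxylic acid or an amine, would read out.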